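The source may report more compounds than this note shows. Statements on the series, on what has been measured and on what is new or still open speak of the compounds shown alone.

Measured compounds:
- Compound 1, `CC(=N)NCC1CCCc2cc(S(=O)(=O)c3ccccc3)ccc21`: 0.631 nM
- Compound 2, `NC[C@@H]1CCCc2cc(S(=O)(=O)c3c[nH]c4ccccc34)ccc21`: 0.0501 nM
- Compound 3, `O=S(=O)(c1cccc(F)c1)c1ccc2c(c1)CCC[C@H]2CN1CC(O)C1`: 0.1 nM

All three were tested in an assay on isolated protein for displacement of a labelled ligand from 5-hydroxytryptamine receptor 6 (Homo sapiens); on this read-out lower numbers stand for stronger inhibition and higher numbers for weaker inhibition. Among the three numbers, compound 3 holds the second highest. Compound 2 is its nearest neighbour, and the gap between the two lies within the scatter, so the two cannot be told apart. Compound 1 is the furthest from compound 3, and that gap lies beyond the scatter, so compound 1 is the weaker of those two.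

The step under consideration leads from compound 3 to compound 4, `CS(=O)(=O)NC[C@@H]1CCCc2cc(S(=O)(=O)c3cccc(F)c3)ccc21`, which has not yet been measured in this assay. The change is methanesulfonamido in place of 3-hydroxyazetidin-1-yl on a saturated chain carbon bound to a saturated ring carbon. Within the data shown here, in the three measured compounds the group on this saturated chain carbon differs each time, and the numbers spread widely, so this position clearly matters; no step of this exact kind has been measured. A step beyond the scatter, toward a higher number, is expected. Compound 4 is estimated at 1.6 nM, within 0.2 nM to 12 nM, which would mean a step of a 16-fold higher number from compound 3 to compound 4 (1.20 log units; beyond the scatter).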

Compound 4, inhibition constant: 0.2 nM
Estimate against measurement, compound 4: 8.0-fold (0.90 log units) above; low and high end bracket the measured number.
By their numbers in this assay, from the lowest: compounds 2, 3 and 4 (each within the scatter of the next, the first and the last beyond it); then compound 1.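

In this assay the change to methanesulfonamido on a saturated chain carbon bound to a saturated ring carbon gives a 2.0-fold higher number from compound 3 to compound 4 (0.30 log units; within the scatter) and so leaves the two compounds indistinguishable. Among these compounds, this is the first measured comparison at this position in which only one place differs, and it shows that an open group with two double bonds outside aromatic rings can replace a four-membered ring with no readable change in the number. The two groups also match in heavy atoms, hydrogen-bond donors and hydrogen-bond acceptors, but nothing measured here explains the result.

On these data alone, whether this tolerance extends to other groups remains open. An acetamido group, a longer ethanesulfonamido chain or a carboxylic acid at this position could show where it ends.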